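Compound 1 loses a fluoro: what follows?

The source may report more compounds than this note shows. Statements on the series, on what has been measured and on what is new or still open speak of the compounds shown alone.

- Compound 1 `O=[N+]([O-])c1cn2c(n1)OC(COc1cccc(-c3ccc(F)nc3F)n1)CC2`: > 64000 nM
- Compound 2 `O=[N+]([O-])c1cn2c(n1)OC(COc1ccc(-c3ccc(F)nc3F)cn1)CC2`: > 64000 nM
- Compound 3 `O=[N+]([O-])c1cn2c(n1)OC(CN1CCC(c3ccc(F)cc3)CC1)CC2`: > 64000 nM

Each of these values is a limit, not a number. In an ADME assay on MRC5 cells (Homo sapiens) for cytotoxicity, read by resazurin assay, with a stated time of 72 h (on this read-out lower numbers stand for stronger inhibition and higher numbers for weaker inhibition), compound 1 gives > 64000 nM, which is such a limit. Compound 1 therefore stands with the others at the limit of > 64000 nM in this assay, at which 3 of the 3 values shown sit.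

Compound 4 `O=[N+]([O-])c1cn2c(n1)OC(COc1cccc(-c3ccc(F)nc3)n1)CC2` differs from compound 1 in one place: hydrogen in place of fluoro on an aromatic carbon. In words, hydrogen takes the place of fluoro on an aromatic carbon, turning 2,6-difluoropyridin-3-yl into 6-fluoropyridin-3-yl. Among the compounds with values here, no measured pair shows this change. The expectation therefore rests on compound 1, at > 64000 nM, and no change beyond the scatter is expected in either direction in this assay. The expected result is a number no higher from compound 1 to compound 4 (the limit leaves the size open). Compound 4 is estimated at 64000 nM, with an expected range from 30000 nM to 64000 nM.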

Compound 4, half-maximal inhibitory concentration: 35000 nM
Compound 4: the middle estimate sits 1.8-fold (0.26 log units) above what was measured, within the range that was stated.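

Compound 4 alone among the compounds shown gives a number rather than a limit: the limit of > 64000 nM in this assay, at which 3 of the 4 values shown sit. In this assay, hydrogen in place of fluoro on an aromatic carbon, next to the ring nitrogen, gives an at least 1.8-fold lower number from compound 1 to compound 4 (0.26 log units; that floor lies within the scatter). Going by these compounds, the value of compound 1 is a limit, and the full size of this step stays open.

The compounds shown leave open whether chloro, methyl or an amine in this place would give a similar reading. They also leave open whether the same change on compound 2 would give a number.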